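The source may report more compounds than this note shows. Statements on the series, on what has been measured and on what is new or still open speak of the compounds shown alone.

Measured in an ADME assay on MT4 cells (Homo sapiens) for cytotoxicity, read by MTT assay, with a stated time of 96 h; a lower number here means that less compound is tolerated, a higher number that more compound is tolerated:
compound 1 `C/C(=N\NC(N)=O)c1ccc2[nH]c(-c3ccccc3)nc2c1`: "not determined" (no result reported)
compound 2 `C/C(=N\NC(N)=S)c1ccc2[nH]c(-c3ccccc3)nc2c1`: >= 100000 nM

Compound 2 is known only as a limit of the assay, >= 100000 nM, and not as a number. Compound 3 `C/C(=N\NC(N)=S)c1ccc2[nH]c(C3CCCCC3)nc2c1` carries cyclohexyl in place of phenyl on an aromatic carbon. Among the measured compounds shown here, the series holds no measured step to calibrate this change in this assay. The expected change is small, towards less compound tolerated, and may stay within the scatter. The estimated step is an at least 1.6-fold lower number from compound 2 to compound 3 (0.22 log units; that floor lies within the scatter). For compound 3 the expected value is 60000 nM, with an estimated range of 20000 nM to 100000 nM.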

Compound 3, half-maximal cytotoxic concentration: 48000 nM
Estimate against measurement, compound 3: 1.3-fold (0.10 log units) above; measured number inside the range.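

On the aromatic carbon between two ring nitrogen atoms, the nature of the six-membered ring registers in this assay: cyclohexyl in place of phenyl gives an at least 2.0-fold lower number from compound 2 to compound 3 (0.31 log units; beyond the scatter). Among the compounds shown here, this is the first step that can be read at this position, and it lies beyond the scatter. Compound 2 holds only a limit of the assay, so the step is a floor and its full size remains unknown: the limit of >= 100000 nM in this assay, at which 1 of the 3 values shown sits.

Open, going by these compounds, is how an amine, a methyl or a carboxylic acid on this carbon would read in this assay. For the compounds shown here, with only this one change, no trend at this position can be stated.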